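The source may report more compounds than this note shows. Statements on the series, on what has been measured and on what is new or still open speak of the compounds shown alone.

Three compounds have been measured in an assay on U2OS cells for activation of nuclear factor erythroid 2-related factor 2 (Homo sapiens), read by beta-arrestin recruitment, with a stated time of 6 h; a lower number here means that less compound is needed, a higher number that more compound is needed for the effect:

Compound 1, `O=S(=O)(/C=C/c1ccccn1)c1cccc(Cl)c1`, gives 1430 nM.
Compound 2, `O=S(=O)(/C=C/c1ccc(Cl)cn1)c1cccc(Cl)c1`, gives 1510 nM.
Compound 3, `O=S(=O)(/C=C/c1ccccn1)c1ccc(Cl)cc1`, gives 1730 nM.

Compound 2 is compound 1 with one change: chloro in place of hydrogen on an aromatic carbon. That change made a step of a 1.1-fold higher number from compound 1 to compound 2 (0.02 log units; within the scatter), so adding the chloro group to the nitrogen-bearing ring left the number essentially where it was. Compound 3 carries the same atoms as compound 1 joined differently; the difference between the two cores is not broken down here. Its number lies within the scatter of those of compound 1 and compound 2, so the three measured compounds cannot be told apart in this assay.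

Compound 4, `O=S(=O)(/C=C/c1ccc(Cl)cn1)c1ccc(Cl)cc1`, has not yet been measured. It stands to compound 3 as compound 2 stands to compound 1: chloro in place of hydrogen on an aromatic carbon. The place of the change is described in the same words in both pairs, so this is the same change applied to a different core. Going by the values given here, only one example of it exists among the measured compounds, so the expectation for compound 4 rests on a single step. The step from compound 3 to compound 4 in this assay is expected to be about a 1.1-fold higher number from compound 3 to compound 4 (0.03 log units; within the scatter), close to the earlier 1.1-fold higher number from compound 1 to compound 2 (0.02 log units; within the scatter), because the same change gave a 1.1-fold higher number from compound 1 to compound 2 (0.02 log units; within the scatter) in the other pair. For compound 4 the estimated value is 1850 nM, with a likely range from 900 nM to 3800 nM.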

Compound 4, half-maximal effective concentration: 3160 nM
The estimate for compound 4 lay 1.7-fold (0.23 log units) below the measured number, and the stated range covers the measured number.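

In this assay, putting chloro in place of hydrogen on an aromatic carbon of the ring with one nitrogen gave a 1.8-fold higher number from compound 3 to compound 4 (0.26 log units; within the scatter). Set beside the earlier example of the same change, the two steps cannot be told apart: the same change on two cores in this assay, a 1.1-fold higher number (0.02 log units; within the scatter) from compound 1 to compound 2 and a 1.8-fold higher number (0.26 log units; within the scatter) from compound 3 to compound 4, 1.7-fold (0.24 log units) apart, within the scatter of two such steps

So, as far as these two pairs can show, the change carries from the core of compound 1 to the core of compound 3 without a detectable difference in what it does, but this does not show that the chloro group has any real effect in this assay, since neither step rises above the ordinary spread of repeated measurements, and two pairs say nothing about how it would behave on other cores.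

The compounds shown leave open what a group other than chloro would do at this place on the ring, for example a methoxy group, an amine or a carboxylic acid, and whether any of these would give a step clearly beyond the scatter. They also leave open whether a chloro group at this place would behave the same way on a core with a different ring in place of the chlorinated one.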